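The source may report more compounds than this note shows. Statements on the series, on what has been measured and on what is new or still open speak of the compounds shown alone.

Three compounds have numbers in a functional assay on CHO cells for antagonist activity at transient receptor potential cation channel subfamily V member 1 (Rattus norvegicus); a lower number here means a stronger inhibitor, a higher number a weaker inhibitor. Compound 1 `CC(C)(C)c1ccc(CNC(=O)C(C)(C)c2ccc(NS(C)(=O)=O)c(F)c2)cc1` gives 467 nM, compound 2 `CC(C)(C)c1ccc(CNC(=O)C2(c3ccc(NS(C)(=O)=O)cc3)CC2)cc1` gives 1770 nM, and compound 3 `CC(C(=O)NCc1ccc(Cl)cc1)c1ccc(NS(C)(=O)=O)c(F)c1` gives 367 nM. Compound 3 has the lowest of the three numbers; the number of compound 1 lies within the scatter of it, the number of compound 2 lies beyond it. Compound 3 and compound 1 sit within the scatter of each other. No order between the two is claimed.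

Compound 4 `CC(C(=O)NCc1ccc(C(F)(F)F)cc1)c1ccc(NS(C)(=O)=O)c(F)c1` keeps the core of compound 3 and changes only the benzylamide end: trifluoromethyl in place of chloro on an aromatic carbon. Among the compounds with values here, no step between measured compounds covers this exchange, so nothing tells how large it should be. Both groups lack donors and acceptors and carry no charge, as counted above, so a step of no more than the usual scatter is expected, with no preferred direction. The expected step from compound 3 to compound 4 in this assay is a 1.1-fold lower number from compound 3 to compound 4 (0.06 log units; within the scatter). Compound 4 is therefore estimated at 320 nM, within a range from 110 nM to 950 nM.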

Compound 4, inhibition constant: 274 nM
Compound 4: middle estimate off by 1.2-fold (0.07 log units), on the high side, within the range that was stated.
By their numbers in this assay, from the lowest: compounds 4, 3 and 1 (each within the scatter of the next); then compound 2.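

In this assay, within the data shown here, trifluoromethyl in place of chloro on an aromatic carbon para to a large group gives a 1.3-fold lower number from compound 3 to compound 4 (0.13 log units; within the scatter) and this is the only step between compounds that differ in one place. At this position, the larger trifluoromethyl group, with 4 heavy atoms against 1 for chloro, is therefore not separated from chloro, and no order between the two is claimed. No measurement shown gives a reason for this result.

Still open, going by these compounds, is how this position responds to groups of another kind, such as an amine, a carboxylic acid or a longer alkyl chain. Also open, on these data alone, is whether the same exchange gives a step of similar size on a different core, such as the core of compound 1.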